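This account rests on a few compounds, and the source may have more. Where it says the series, first, only, none or still open, it means among the compounds named here.

Measured so far:
- compound 1, `O=C(Nc1nc2ccc(Oc3ccc(F)c(NCc4cccc(C(F)(F)F)c4)c3)cc2s1)C1CC1`: "not determined" (no result reported)
- compound 2, `COc1cccc(NC(=O)Nc2cc(Oc3ccc4nc(NC(=O)C5CC5)sc4c3)ccc2F)c1`: > 50000 nM

Working notes on the series. In an ADME assay on HT-29 cells (Homo sapiens) for cytotoxicity, read by luminescence and CellTiter-Glo, with a stated time of 12 h (on this read-out lower numbers stand for higher toxicity in this test and higher numbers for lower toxicity in this test), compound 1 carries no result, only "not determined" (no result reported). For compound 2 the entry in this assay is a limit of the assay rather than a number, given as > 50000 nM. So compound 2 stands at the upper edge of what the test reports, which is where the limit of > 50000 nM in this assay, at which 1 of the 2 values shown sits, places it; nothing measured in the series sits below that edge, and no step between two measured compounds can be read off.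

The next compound, compound 3, is `O=C(Nc1cccc(Br)c1)Nc1cc(Oc2ccc3nc(NC(=O)C4CC4)sc3c2)ccc1F`. The change from compound 2 to compound 3 is bromo in place of methoxy on an aromatic carbon. Among the compounds with values here, no measured pair shows what such a change does in this assay.

With only a limit as the starting point, the expected step that the limit leaves unreadable from compound 2 to compound 3 is taken as none beyond the usual scatter, and the most likely outcome is again a limit. Compound 3 is therefore estimated at 60000 nM in this assay, with a range from 20000 nM to 150000 nM.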

Compound 3, half-maximal cytotoxic concentration: > 50000 nM
Compound 3: a limit, no number; the forecaster's own chance of this, stated with the estimate: 70%; the middle value is on the limit's open side.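

In this assay no step can be read from compound 2 to compound 3, since the entries for both compounds are limits of the assay and not numbers: the limit of > 50000 nM in this assay, at which 2 of the 3 values shown sit.

The compounds shown leave open what bromo in place of methoxy does to the read-out, and whether any compound in the series gives a number within the reported range of this assay.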